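From (4-methylphenyl)sulfonyl to (4-fluorophenyl)sulfonyl

The source may report more compounds than this note shows. Statements on the series, on what has been measured and on what is new or still open speak of the compounds shown alone.

Measured in a functional assay on HepG2 cells (Homo sapiens) for cytotoxicity, read by MTT assay, with a stated time of 24 h (on this read-out higher numbers stand for weaker inhibition and lower numbers for stronger inhibition), so far:
- compound 1 `O=C1/C(=C/c2ccncc2)CN(S(=O)(=O)c2ccccc2)C/C1=C\c1ccccc1C(F)(F)F` gives 7020 nM
- compound 2 `Cc1ccc(S(=O)(=O)N2C/C(=C\c3ccncc3)C(=O)/C(=C/c3ccccc3C(F)(F)F)C2)cc1` gives 4640 nM

In this assay compound 2 stands level with compound 1, the two numbers lying within the scatter of each other. Compound 3 `O=C1/C(=C/c2ccncc2)CN(S(=O)(=O)c2ccc(F)cc2)C/C1=C\c1ccccc1C(F)(F)F` is still unmeasured. It differs from compound 2 by fluoro in place of methyl on an aromatic carbon, para to a large group (fluoro in place of methyl on an aromatic carbon), and the rest of the structure is the same.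

For the measured compounds named here, one measured step bears on this carbon: a 1.5-fold lower number from compound 1 to compound 2 (0.18 log units; within the scatter), methyl in place of hydrogen. Going by the values given here, that step is within the scatter, but it is a single step, and no measured compound carries fluoro here. The data therefore give no support for a real shift in this assay in either direction, and none beyond the scatter is expected. The expected change is a 1.2-fold higher number from compound 2 to compound 3 (0.07 log units; within the scatter). The estimate for compound 3 is 5500 nM, with an expected range from 2800 nM to 10500 nM.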

Compound 3, half-maximal inhibitory concentration: 4010 nM
The estimate for compound 3 lay 1.4-fold (0.14 log units) above the measured number, within the range that was stated.
By their numbers in this assay, from the lowest: compounds 3, 2 and 1 (each within the scatter of the next).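

In this assay, the first fluoro at this carbon gives a 1.2-fold lower number from compound 2 to compound 3 (0.06 log units; within the scatter), so the change from 4-methylphenyl to 4-fluorophenyl leaves the number within the scatter. Measured against hydrogen on the same carbon, the result is a 1.8-fold lower number from compound 1 to compound 3 (0.24 log units; within the scatter), and this step is also within the scatter. With hydrogen, methyl and fluoro now all measured at this carbon on the otherwise unchanged structure, the three compounds cannot be told apart in this assay, which extends the earlier reading from a single step to a set of three compounds, although no evidence is available to explain the result.

As far as these compounds go, these three substituents span only a narrow set of small groups, so it remains open whether an amine, a carboxylic acid or a longer chain on this carbon would move the number beyond the scatter. From the compounds shown here alone, it is also open whether the same flat result would hold if the trifluoromethyl group elsewhere on the shared core were replaced, since all three compounds carry that group unchanged.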